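Aryl variation on the semicarbazone: bromo to hydroxy

The source may hold more compounds than are shown below. What is called first, only, known or untested is meant among the compounds shown, and "the series" means these compounds.

Measured compounds, with their values in a functional assay on NCI-H460 cells (Homo sapiens) for cytotoxicity, read by MTT assay, with a stated time of 72 h; on this read-out higher numbers stand for weaker inhibition and lower numbers for stronger inhibition:
compound 1 `CN(C)CCn1cnnc1-c1cc(Oc2ccc(NC(=O)N/N=C/c3c[nH]c4ccccc34)cc2F)ccn1` gives 1630 nM
compound 2 `COc1ccc(/C=N/NC(=O)Nc2ccc(Oc3ccnc(-c4nncn4CCN(C)C)c3)c(F)c2)c(OC)c1` gives 1570 nM
compound 3 `CN(C)CCn1cnnc1-c1cc(Oc2ccc(NC(=O)N/N=C/c3cccc(Br)c3)cc2F)ccn1` gives 520 nM

The three share one core and differ only in the aryl ring on the carbon with a double bond to nitrogen. Compound 3 holds the lowest number of the three; the steps into it are a 3.0-fold lower number from compound 2 to compound 3 (0.48 log units; beyond the scatter) and a 3.1-fold lower number from compound 1 to compound 3 (0.50 log units; beyond the scatter). The remaining pair shows a 1.0-fold lower number from compound 1 to compound 2 (0.02 log units; within the scatter).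

Compound 4 `CN(C)CCn1cnnc1-c1cc(Oc2ccc(NC(=O)N/N=C/c3cccc(O)c3)cc2F)ccn1` continues from compound 3 by the change (hydroxy in place of bromo on an aromatic carbon). Among the compounds with values here, no measured step swaps a bromo for a hydroxy, so none bears on this change directly. Within the data shown here, the two steps into compound 3 show only that the aryl ring at this position moves the number in this assay by a modest amount, and that 3-bromophenyl gave the lowest number so far. With the bromo gone, compound 4 is expected to give back part of that gain, an estimated step of a 2.3-fold higher number from compound 3 to compound 4 (0.36 log units; beyond the scatter), toward the range of compound 1 and compound 2, with wide uncertainty. For compound 4 the estimated value is 1200 nM, range 500 nM to 3000 nM.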

Compound 4, half-maximal inhibitory concentration: 780 nM
Beside the measured number, compound 4's estimate is 1.5-fold (0.19 log units) above it, within the range that was stated.
By their numbers in this assay, from the lowest: compounds 3, 4, 2 and 1 (each within the scatter of the next, the first and the last beyond it).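

In this assay, the change from 3-bromophenyl to 3-hydroxyphenyl gives a 1.5-fold higher number from compound 3 to compound 4 (0.18 log units; within the scatter) and so leaves no readable difference, which shows that a hydroxy, with its hydrogen-bond donor and acceptor, can stand meta to a large group where the bromo stood without a step beyond the scatter. Against the other two aryl groups, 3-hydroxyphenyl gives a 2.0-fold lower number from compound 2 to compound 4 (0.30 log units; within the scatter) and also a 2.1-fold lower number from compound 1 to compound 4 (0.32 log units; beyond the scatter) as its second step, so compound 4 separates clearly from compound 1 only, whereas compound 3 separates from both compound 1 and compound 2. Nothing available explains why bromo and hydroxy read alike at this place, and no supporting data bear on this result.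

Still open, as far as these compounds go, is whether an amine or a carboxylic acid on this same aromatic carbon would also stay within the scatter of compound 3 and compound 4, or would fall back toward compound 1 and compound 2. From the compounds shown here alone, the four compounds also rest on a single cell line, so it remains open whether the closeness of bromo and hydroxy holds in any other cell line.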